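Stereo-inverted ring in the hydroxamate acrylamide

This account rests on a few compounds, and the source may have more. Where it says the series, first, only, none or still open, it means among the compounds named here.

Among the measured compounds shown here, compound 2 `O=C(/C=C/c1cn([C@@H]2C[C@@H](C(=O)O)N(Cc3ccccc3)C2)nn1)NO` is the only compound with a number in an assay on Sf9 cells for inhibition of histone deacetylase 11 (Homo sapiens), read by fluorescence, tested at 0.5 uM; a lower number here means less inhibition, a higher number more inhibition at the concentration tested (going by the name of the read-out): compound 2 gives 12%. Compound 1 `O=C(NO)c1ccc(-c2cn([C@@H]3C[C@@H](C(=O)O)N(Cc4ccccc4)C3)nn2)cc1` sits at a limit of this assay rather than at a number. In this assay compound 1 gives < 10%. For the measured compounds named here, the only measured step, a number at least 2 percentage points higher from compound 1 to compound 2 (that floor lies within the scatter), has its floor set by the limit of < 10% in this assay, at which 1 of the 2 values shown sits, and lies within the scatter of this assay.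

Compound 3 `O=C(/C=C/c1cn([C@H]2C[C@H](C(=O)O)N(Cc3ccccc3)C2)nn1)NO` differs from compound 2 as follows: the two compounds have the same atoms and bonds and differ only in configuration as drawn: 2 of 3 stereo elements differ; a stereocentre at a saturated ring carbon is drawn R in compound 2 and S in compound 3; a stereocentre at a saturated ring carbon is drawn S in compound 2 and R in compound 3. No measured step in the series changes configuration at the ring; the one step shown, a number at least 2 percentage points higher from compound 1 to compound 2 (that floor lies within the scatter), exchanges a 4-(hydroxycarbamoyl)phenyl for a 2-(hydroxycarbamoyl)ethenyl on an aromatic carbon and says nothing about the ring stereocentres. No step size in this assay can therefore be derived from the data, and the expectation stays near compound 2 with a wide range and a real chance that only a limit is reported. Compound 3 is accordingly expected at 10%, between 2% and 22%. The step from compound 2 to compound 3 is estimated as a number 2 percentage points lower from compound 2 to compound 3 (within the scatter), no change beyond the scatter.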

Compound 3, a percentage reported as inhibition, at one concentration (the size of the read-out at that concentration, not a potency): 14%
The estimate for compound 3 lay 4 percentage points below the measured number, and the stated range covers the measured number.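

In this assay, among the compounds shown here, the step of a number 2 percentage points higher from compound 2 to compound 3 (within the scatter) is the first to touch the two saturated ring stereocentres, and it is the first comparison between two numbers rather than between a number and a limit. Swapping both centres together, R to S at one and S to R at the other, gives no difference beyond the scatter at the one concentration tested. With the 2-(hydroxycarbamoyl)ethenyl group in place, this read-out therefore does not separate the two drawn configurations, and the comparison concerns configuration alone: the fact that compounds 2 and 3 differ only in the configuration as drawn

The pair leaves open what happens when only one of the two centres is inverted, and whether the same insensitivity holds with the 4-(hydroxycarbamoyl)phenyl group, or with a methyl ester or primary amide in place of the carboxylic acid on the ring. As far as these compounds go, a reading at one concentration also gives no potency, so any difference between the two configurations that does not show at this concentration remains open in this assay.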